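The compounds below may be only part of what the source reports. "The series", "measured", "known", "first", "only" and "open" are said of these compounds alone.

Measured compounds in a functional assay on SW-620 cells (Homo sapiens) for inhibition, read by MTT assay, with a stated time of 48 h; on this read-out lower numbers stand for stronger inhibition and higher numbers for weaker inhibition:

Compound 1 `Cc1ccc(NC(=S)NC(=O)c2ccc(OCc3cccc(Cl)c3Cl)cc2)cc1-c1nc2ccccc2[nH]1`: in this assay compound 1 reaches only the limit > 100000 nM, a limit and not a number.
Compound 2 `Cc1ccc(COc2ccc(C(=O)NC(=S)Nc3ccc(C)c(-c4nc5ccccc5[nH]4)c3)cc2)cc1`: in this assay compound 2 gives 60900 nM.
Compound 3 `Cc1ccc(NC(=O)NC(=O)c2ccc(OCc3cccc(Cl)c3Cl)cc2)cc1-c1nc2ccccc2[nH]1`: in this assay compound 3 gives 42100 nM.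

Compound 1 and compound 2 share a core and differ in one place, (4-methylphenyl in place of 2,3-dichlorophenyl on a saturated chain carbon bound to an oxygen on an aromatic ring). The step of an at least 1.6-fold lower number from compound 1 to compound 2 (0.21 log units; that floor lies within the scatter) rests on the limit of > 100000 nM in this assay, at which 1 of the 3 values shown sits, and lies within the scatter, so nothing more than a floor can be read from it. Compound 3 carries a different core from compound 1; the difference between the two cores is not broken down here. Compound 3 and compound 2 sit within the scatter of each other, so no order between them is claimed.

The unmeasured compound 4 `Cc1ccc(COc2ccc(C(=O)NC(=O)Nc3ccc(C)c(-c4nc5ccccc5[nH]4)c3)cc2)cc1` stands to compound 3 as compound 2 stands to compound 1: 4-methylphenyl in place of 2,3-dichlorophenyl on a saturated chain carbon bound to an oxygen on an aromatic ring. This is the same change, at the same place, as from compound 1 to compound 2. The earlier step lies within the scatter, so a step of a similar small size is expected here, and the estimate is built on compound 3 at 42100 nM moved by about as much. The step from compound 3 to compound 4 is expected to be a 1.3-fold lower number from compound 3 to compound 4 (0.12 log units; within the scatter). For compound 4 the expected value in this assay is 32000 nM, with a range from 12000 nM to 90000 nM.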

Compound 4, half-maximal inhibitory concentration: 26000 nM
The estimate for compound 4 lay 1.2-fold (0.09 log units) above the measured number; measured number inside the range.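

In this assay, 4-methylphenyl in place of 2,3-dichlorophenyl on a saturated chain carbon bound to an oxygen on an aromatic ring gives a 1.6-fold lower number from compound 3 to compound 4 (0.21 log units; within the scatter), so on the core of compound 3 this change has no effect that can be told from the scatter. The comparison with the core of compound 1 shows neither that the change carries over with a size of its own nor that its size depends on the core: the same change on two cores in this assay, an at least 1.6-fold lower number (0.21 log units; that floor lies within the scatter) from compound 1 to compound 2 and a 1.6-fold lower number (0.21 log units; within the scatter) from compound 3 to compound 4; the limit leaves it open whether they differ. Compound 1 stands at a limit and not at a number, so the step from that core remains a floor and the comparison cannot be sharpened: the limit of > 100000 nM in this assay, at which 1 of the 4 values shown sits.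

Left open is whether a group of another kind at this place, such as an amine or a carboxylic acid on the phenyl ring, or a longer chain in place of the saturated chain carbon, would give a step beyond the scatter in this assay. Also open, as far as these compounds go, is how this same change reads on a further core where both partners give numbers rather than a limit.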